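Swapping the Aryl Group on the Amide-Type Nitrogen

The source may hold more compounds than are shown below. What is called first, only, known or untested is meant among the compounds shown, and "the series" means these compounds.

Measured in a functional assay on RT-112 cells (Homo sapiens) for antiproliferative activity, read by MTT assay, with a stated time of 72 h; a higher number here means a weaker inhibitor of growth, a lower number a stronger inhibitor of growth:
- compound 1 `COc1cc(Nc2ncnc3c(NC(=O)Nc4ccc(C)cc4C)cccc23)cc(OC)c1`: 1290 nM
- compound 2 `COc1cc(Nc2ncnc3c(NC(=O)Nc4ccc(Cl)c(C(F)(F)F)c4)cccc23)cc(OC)c1`: > 20000 nM (a limit of the assay, not a number)
- compound 3 `COc1cc(Nc2ncnc3c(NC(=O)Nc4cccc(C)c4C)cccc23)cc(OC)c1`: 5910 nM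

Of the two true numbers, compound 3 holds the higher, making it the weaker of that pair. Compound 4 `COc1cc(Nc2ncnc3c(NC(=O)Nc4ccc(Cl)cc4Cl)cccc23)cc(OC)c1` differs from it in one place: 2,4-dichlorophenyl in place of 2,3-dimethylphenyl on an amide-type nitrogen. It carries 2,4-dichlorophenyl in place of 2,3-dimethylphenyl on an amide-type nitrogen.

Within the data shown here, two measured steps bear on this. Replacing 2,4-dimethylphenyl with 2,3-dimethylphenyl gave a 4.6-fold higher number from compound 1 to compound 3 (0.66 log units; beyond the scatter), a modest step. Replacing it with 4-chloro-3-(trifluoromethyl)phenyl gave an at least 15-fold higher number from compound 1 to compound 2 (1.19 log units; beyond the scatter), a large one. Neither step tests 2,4-dichlorophenyl directly, so these point in opposite directions only loosely. A small move towards a lower number is expected, and the expected step is a 2.0-fold lower number from compound 3 to compound 4 (0.29 log units; within the scatter). For compound 4 the estimate is 3000 nM, with an expected range of 800 nM to 15000 nM.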

Compound 4, concentration for 50% growth inhibition: 3060 nM
Compound 4: the middle estimate sits 1.0-fold (0.01 log units) below what was measured; the range from low to high includes it.
By their numbers in this assay, from the lowest: compound 1; then compounds 4 and 3 (each within the scatter of the next). At a limit, above all of these: compound 2.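

Chlorine on this aryl ring does not by itself bring the loss seen with 4-chloro-3-(trifluoromethyl)phenyl in this assay: the change gives an at least 6.5-fold lower number from compound 2 to compound 4 (0.81 log units; beyond the scatter). Compound 2 stands at a limit, not a number: the limit of > 20000 nM in this assay, at which 1 of the 4 values shown sits.

The 2,4-dichlorophenyl group shows no clear difference from 2,3-dimethylphenyl, with a 1.9-fold lower number from compound 3 to compound 4 (0.29 log units; within the scatter), yet it remains weaker than 2,4-dimethylphenyl, with a 2.4-fold higher number from compound 1 to compound 4 (0.38 log units; beyond the scatter). Still open, as far as these compounds go, is how a ring with a single chlorine or a single methyl would compare, and what a methoxy group or an amine on this ring would do.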